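From Acetyl to (2-Chlorophenyl)carbonyl on the Ring Nitrogen

The compounds below may be only part of what the source reports. "The series", "measured", "known", "first", "only" and "open" are said of these compounds alone.

Compound 3 `CC(=O)N1c2ccccc2CCC1C(=O)Nc1ccccc1O` was run in a functional assay on NCI-H23 cells (Homo sapiens) for cytotoxicity, read by sulforhodamine B assay, with a stated time of 72 h (a higher number here means a weaker inhibitor of growth, a lower number a stronger inhibitor of growth), and gives 65700 nM. Going by the values given here, compound 2 `O=C(Nc1cc(C(F)(F)F)cc(C(F)(F)F)c1)C1CCc2ccccc2N1C(=O)c1ccccc1Cl` is the only other compound with a number in this assay and gives 2080 nM, so compound 3 holds the higher of the two numbers, and that gap lies beyond the scatter. In this assay compound 1 `O=C(Nc1ccc(C(F)(F)F)cc1)c1ccc2ccccc2n1` reaches only a limit, > 90000 nM, which is the limit of > 90000 nM in this assay, at which 1 of the 3 values shown sits. Compound 4 `O=C(Nc1ccccc1O)C1CCc2ccccc2N1C(=O)c1ccccc1Cl` has not been measured; it differs from compound 3 in one place: 2-chlorophenyl in place of methyl on a carbonyl carbon. Because compound 2 carries the same (2-chlorophenyl)carbonyl group on its ring nitrogen and gives 2080 nM, a lower number is expected for compound 4. The expected step of a 4.4-fold lower number from compound 3 to compound 4 (0.64 log units; beyond the scatter) should exceed the scatter. Compound 4 is estimated at 15000 nM, between 4000 nM and 50000 nM.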

Compound 4, concentration for 50% growth inhibition: 46900 nM
For compound 4 the middle estimate is 3.1-fold (0.50 log units) below the measured one; the measured number falls inside the stated range.
By their numbers in this assay, from the lowest: compound 2; then compounds 4 and 3 (each within the scatter of the next). At a limit, above all of these: compound 1.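

On the ring nitrogen, going from acetyl to (2-chlorophenyl)carbonyl gives a 1.4-fold lower number from compound 3 to compound 4 (0.15 log units; within the scatter) in this assay. With the rest of compound 3 kept, a ring-bearing group at this place therefore leaves the number unchanged within the scatter, so this group alone does not account for compound 2 giving 2080 nM. Nothing measured here explains why the step is so small. The compounds shown leave open whether the same change would matter with the other amide part of compound 2. They also leave open how an amine or a carboxylic acid in place of the 2-chlorophenyl on this carbonyl carbon would behave.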